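The source may report more compounds than this note shows. Statements on the series, on what has been measured and on what is new or still open speak of the compounds shown alone.

Measured so far:
compound 1 `CC(C)c1ccc(C(=O)CC(SCC(=O)O)C(=O)O)cc1` — 3330 nM
compound 2 `Cc1ccc(C(=O)CC(SCC(=O)O)C(=O)O)c(Cl)c1` — 4730 nM

In a functional assay on HeLa cells (Homo sapiens) (a lower number here means a stronger inhibitor, a higher number a weaker inhibitor), compound 1 gives 3330 nM, the lowest of the two numbers, while compound 2 gives 4730 nM; the distance between them lies within the scatter. Compound 3 `O=C(O)CSC(CC(=O)c1ccc(Br)cc1)C(=O)O` remains to be measured. The change from compound 1 is bromo in place of isopropyl on an aromatic carbon. Among the measured compounds shown here, no step between measured compounds is known, so the expectation rests on this exchange alone. The expected step is small, a 1.2-fold higher number from compound 1 to compound 3 (0.08 log units; within the scatter), with no direction beyond the scatter claimed. Compound 3 is therefore estimated at 4000 nM, within a range from 1500 nM to 11000 nM.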

Compound 3, half-maximal inhibitory concentration: 9510 nM
Beside the measured number, compound 3's estimate is 2.4-fold (0.38 log units) below it, and the stated range covers the measured number.
By their numbers in this assay, from the lowest: compounds 1, 2 and 3 (each within the scatter of the next, the first and the last beyond it).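

In this assay, bromo in place of isopropyl on this aromatic carbon gives a 2.9-fold higher number from compound 1 to compound 3 (0.46 log units; beyond the scatter). Among the compounds shown here, this is the first step that changes one place only, and it shows that the position para to a large group is sensitive to the exchange, modestly but beyond the scatter. No evidence at hand accounts for this step. The compounds shown leave open where a methoxy group or an amine on this aromatic carbon would fall relative to isopropyl and bromo. They also leave open whether a longer alkyl chain there would keep the number of compound 1.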